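Adding a methyl to the outer ring of compound 3

A few compounds are considered here, and "the series" means these few. Any claim that something is new, unique, unknown or untested is made for them only; others in the source may bear on it.

Three compounds share a core in which an aromatic aldehyde is joined through a nitrogen-carbon double bond to a fused two-ring system. Compound 1 `Cc1ccc(Oc2ccc(/C=N/n3c(C)nc4ccccc4c3=O)cc2)cc1` carries a methyl on that core and a methyl on the outer phenoxy ring; in a physicochemical assay for lipophilicity, in phosphate buffer, measured as octanol-water partition (on this read-out lower numbers stand for lower lipophilicity and higher numbers for higher lipophilicity), compound 1 gives 4.32. Compound 2 `O=c1c2ccccc2nc(-c2ccccc2)n1/N=C/c1ccc(Oc2ccc([N+](=O)[O-])cc2)cc1` carries a phenyl on the core and a nitro on the outer ring, and in this assay compound 2 gives 6.12. Compound 3 `O=c1c2ccccc2nc(-c2ccccc2)n1/N=C/c1ccc(Oc2ccccc2)cc1` keeps the phenyl but has hydrogen in place of the nitro; in this assay compound 3 gives 6.13, the highest of the three numbers, with compound 1 far lower and compound 2 essentially level with it, as the step of a number 0.01 log units higher from compound 2 to compound 3 (within the scatter) shows.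

Compound 4 `Cc1ccc(Oc2ccc(/C=N/n3c(-c4ccccc4)nc4ccccc4c3=O)cc2)cc1` differs from compound 3 by one change: methyl in place of hydrogen on an aromatic carbon. Among the measured compounds shown here, no measured step here involves a methyl on its own; the only step recorded concerns the nitro group and was within the scatter. With that in mind a modest rise is expected, a number 0.37 log units higher from compound 3 to compound 4 (beyond the scatter), and compound 4 is estimated at 6.5, between 6.1 and 6.9.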

Compound 4, partition coefficient: 6.29
Estimate against measurement, compound 4: 0.21 log units above; the range from low to high includes it.
By their numbers in this assay, from the lowest: compound 1; then compounds 2, 3 and 4 (each within the scatter of the next).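

At the outer-ring position para to a large group, hydrogen, methyl and nitro cannot be told apart in this assay, since methyl now sits level with both of the others (a number 0.16 log units higher from compound 3 to compound 4 (within the scatter); a number 0.17 log units higher from compound 2 to compound 4 (within the scatter)). Among the compounds shown here, compound 4 also isolates the core change for the first time. It shares the 4-methylphenoxy group with compound 1 and differs only in having phenyl in place of the core methyl (a number 1.97 log units higher from compound 1 to compound 4 (beyond the scatter)), a step well beyond anything seen on the outer ring. No measurement is available that explains either finding.

Going by these compounds, all of these outer-ring comparisons rest on compounds with the phenyl core, so it remains open whether the same flatness holds with the methyl core. On these data alone, it is also open whether an amine, a carboxylic acid or a longer chain at this position would stay level with the three groups seen so far.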